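Fluoro to methoxy swap in the shared core series

The compounds below may be only part of what the source reports. "The series", "measured", "known", "first", "only" and "open" are said of these compounds alone.

Compound 1 `C/C(=C\c1cc(-c2ccc(F)cc2)cs1)C(N)=O` was run in a functional assay on BGC-823 cells (Homo sapiens) for cytotoxicity, read by CCK-8 assay, with a stated time of 24 h; on this read-out higher numbers stand for weaker inhibition and lower numbers for stronger inhibition. In this assay compound 1 gives only a limit, > 50000 nM, and no number. Compound 2 `C/C(=C\c1nc(-c2ccc(C)cc2)cs1)C(N)=O` likewise sits at a limit; in this assay compound 2 gives > 50000 nM. Compound 3 `C/C(=C\c1cccc(-c2ccccc2)c1)C(N)=O` is the same case; in this assay compound 3 gives > 50000 nM. Compound 1 thus stands at the limit of > 50000 nM in this assay, at which 3 of the 3 values shown sit, with nothing measured that separates it from the other two. Going by the values given here, no pair of measured compounds differs in one place only, so no measured step size can be quoted for the set.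

Compound 4 `COc1ccc(-c2csc(/C=C(\C)C(N)=O)c2)cc1` is not yet measured in this assay. It differs from compound 1 by methoxy in place of fluoro on an aromatic carbon. Among the compounds with values here, with all three measured values sitting at the limit, there is no measured step from which a shift in either direction could be expected, and the expected step is a step that the limit leaves unreadable from compound 1 to compound 4, meaning no change beyond the scatter. Compound 4 is therefore expected to give 60000 nM in this assay, within 20000 nM to 200000 nM, and is most likely to be reported again as a limit rather than a number.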

Compound 4, half-maximal inhibitory concentration: > 50000 nM
Compound 4: a limit, no number; the forecaster's own chance of this, stated with the estimate: 80%; the middle value does not contradict the limit.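

Compound 1 and compound 4 both sit at a limit, not a number, in this assay and so no step can be read between them for methoxy in place of fluoro on an aromatic carbon. The compounds shown leave open whether any change to the shared core gives a measurable value in this assay at all.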